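This account rests on a few compounds, and the source may have more. Where it says the series, first, only, none or still open, it means among the compounds named here.

In a functional assay on A549 cells (Homo sapiens) for antiproliferative activity, read by MTT assay, with a stated time of 48 h (a lower number here means a stronger inhibitor, a higher number a weaker inhibitor), three compounds sharing one core have been measured: compound 1 `COc1cc(-c2cccc3nc(-c4cccc(Br)c4)oc23)cc(OC)c1OC` gives 2100 nM, compound 2 `COc1cc(-c2cccc3nc(-c4ccc(Cl)cc4)oc23)cc(OC)c1OC` gives 5600 nM, and compound 3 `COc1cc(-c2cccc3nc(-c4cccc(C)c4)oc23)cc(OC)c1OC` gives 16700 nM, the highest number and so the weakest of the three. Compound 4 `COc1cc(-c2cccc3nc(-c4cccc(O)c4)oc23)cc(OC)c1OC` carries hydroxy in place of methyl on an aromatic carbon, meta to a large group (hydroxy in place of methyl on an aromatic carbon). The closest guide is the methyl-for-bromo change, an 8.0-fold higher number from compound 1 to compound 3 (0.90 log units; beyond the scatter), and a 3.0-fold higher number from compound 2 to compound 3 (0.47 log units; beyond the scatter) also bears on it; both are modest. Going by the values given here, no hydroxy compound has been measured, so the direction is uncertain, but both other compounds lie lower than compound 3. A modest drop is therefore expected, estimated as a 2.8-fold lower number from compound 3 to compound 4 (0.44 log units; beyond the scatter). For compound 4 the estimated value is 6000 nM, with an expected range from 1500 nM to 25000 nM.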

Compound 4, half-maximal inhibitory concentration: 2000 nM
Compound 4: middle estimate off by 3.0-fold (0.48 log units), on the high side; low and high end bracket the measured number.
By their numbers in this assay, from the lowest: compounds 4 and 1 (each within the scatter of the next); then compound 2; then compound 3.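

Putting hydroxy in place of methyl on this aromatic carbon gives an 8.4-fold lower number from compound 3 to compound 4 (0.92 log units; beyond the scatter), a clear gain from swapping a single atom. Set against bromo at the same place, hydroxy gives a 1.1-fold lower number from compound 1 to compound 4 (0.02 log units; within the scatter), so these two different groups stand level while methyl stays well behind both. The 3-hydroxyphenyl group also improves on the 4-chlorophenyl group, with a 2.8-fold lower number from compound 2 to compound 4 (0.45 log units; beyond the scatter). No available measurement explains these differences. From the compounds shown here alone, whether an amine or a carboxylic acid at this place would match hydroxy and bromo, or fall back towards methyl, remains open.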